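This account rests on a few compounds, and the source may have more. Where it says the series, first, only, none or still open, it means among the compounds named here.

Compound 1 `Cc1ccccc1-c1cc(C(=O)N2CCC3(CC2)CC(=O)c2nn(C(C)(C)C)cc2O3)c2ccccc2n1` gives 1880 nM in a functional assay on A549 cells (Homo sapiens) for inhibition, read by MTT assay, with a stated time of 72 h; a higher number here means a weaker inhibitor, a lower number a stronger inhibitor.
Compound 2 `COc1ccc(-c2cc(C(=O)N3CCC4(CC3)CC(=O)c3nn(C(C)(C)C)cc3O4)c3ccccc3n2)cc1` gives 3740 nM in this assay.
Compound 3 `CN1CCN(c2cc(C(=O)N3CCC4(CC3)CC(=O)c3nn(C(C)(C)C)cc3O4)c3ccccc3n2)CC1` gives > 10000 nM in this assay; this is a limit of the assay and not a number.

Compound 2 carries the highest of the two numbers that were obtained, yet its nearest neighbour, compound 1, lies within the scatter of it: a 2.0-fold higher number from compound 1 to compound 2 (0.30 log units; within the scatter). The one clear movement among the measured compounds is the loss of the aryl group: an at least 5.3-fold higher number from compound 1 to compound 3 (0.72 log units; beyond the scatter), and likewise an at least 2.6-fold higher number from compound 2 to compound 3 (0.42 log units; beyond the scatter), where the limit of > 10000 nM in this assay, at which 1 of the 3 values shown sits, means the true size of those steps is not known.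

Compound 4 `CCOc1cc(C(=O)N2CCC3(CC2)CC(=O)c2nn(C(C)(C)C)cc2O3)c2ccccc2n1` differs from compound 2 by a single change, (ethoxy in place of 4-methoxyphenyl on an aromatic carbon). For the measured compounds named here, no measured step exchanges the aromatic group for so small a substituent, so the two steps to compound 3 are the only guide; both ran toward weaker inhibition when the 4-methoxyphenyl or 2-methylphenyl group was removed from that carbon. A step of similar sense, though of uncertain size, is therefore expected in this assay, and it may well carry compound 4 to the limit of the assay.

Compound 4 is expected to give about 9000 nM, within a range of 3500 nM to 25000 nM, in this assay. This estimate amounts to an expected step of a 2.4-fold higher number from compound 2 to compound 4 (0.38 log units; beyond the scatter).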

Compound 4, half-maximal inhibitory concentration: > 10000 nM
Compound 4 was reported as a limit; the forecaster's own chance of this, stated with the estimate: 45%; middle value at least 1.1-fold (0.04 log units) from the limit.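

Ethoxy, which has no ring, behaves on this aromatic carbon next to the ring nitrogen as 4-methylpiperazin-1-yl did, with an at least 2.6-fold higher number from compound 2 to compound 4 (0.42 log units; beyond the scatter) and an at least 5.3-fold higher number from compound 1 to compound 4 (0.72 log units; beyond the scatter). The earlier drop could have belonged to the 4-methylpiperazin-1-yl group alone, but it now appears with a second, much smaller substituent, so among the four compounds shown only those with a six-membered aromatic ring of carbon on this carbon, compound 1 and compound 2, give a readable number in this assay. The step between compound 3 and compound 4 cannot be read, and the size of the two new steps remains open: the limit of > 10000 nM in this assay, at which 2 of the 4 values shown sit.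

The compounds shown leave open whether an aromatic ring is itself what matters, since a pyridin-3-yl or thiophen-2-yl group on this carbon could separate that from the carbon-only rings of compound 1 and compound 2. They also leave open whether a longer chain such as benzyloxy, which carries a phenyl ring behind the oxygen of the ethoxy group, would bring back a readable number in this assay.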